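A few compounds are considered here, and "the series" means these few. Any claim that something is new, unique, unknown or untested is made for them only; others in the source may bear on it.

Measured so far in a functional assay on PANC-1 cells (Homo sapiens) for antiproliferative activity, read by MTT assay, with a stated time of 48 h; on this read-out higher numbers stand for weaker inhibition and lower numbers for stronger inhibition:
- compound 1 `COc1ccc(-c2c(Nc3cccc(C(F)(F)F)c3)c3ccccc3oc2=O)cc1` gives 49100 nM
- compound 2 `COc1ccc(-c2c(Nc3ccc(NC(C)=O)cc3)c3ccc(O)cc3oc2=O)cc1` gives "not determined" (no result reported)

Compound 2 therefore has no place on the potency scale. For the measured compounds named here, compound 1 supplies the only number, and no step between measured compounds exists. The next compound to be tested is compound 3 `COc1ccc(-c2c(Nc3cccc(C(F)(F)F)c3)c3ccc(O)cc3oc2=O)cc1`. The change is 3-(trifluoromethyl)phenyl in place of 4-acetamidophenyl on a nitrogen on an aromatic ring, with 3-(trifluoromethyl)phenyl in place of 4-acetamidophenyl on a nitrogen on an aromatic ring.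

With no number for compound 2, the size and direction of this step in this assay cannot be read from a starting value. The best available anchor is compound 1, which carries the same 3-(trifluoromethyl)phenyl on that nitrogen and gives 49100 nM. Compound 3 is therefore expected to stay in that weak range, with no difference from compound 1 beyond the usual scatter. With a single anchor, this expectation remains loose. The estimated value for compound 3 is 40000 nM, with an expected range of 15000 nM to 100000 nM.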

Compound 3, half-maximal inhibitory concentration: 67200 nM
Estimate against measurement, compound 3: 1.7-fold (0.23 log units) below; measured number inside the range.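

In this assay, hydroxy in place of hydrogen on an aromatic carbon of the core gives a 1.4-fold higher number from compound 1 to compound 3 (0.14 log units; within the scatter), so with 3-(trifluoromethyl)phenyl on the nitrogen, this change does not separate the two compounds. Compound 2 has no number and the step from it to compound 3 cannot be read, which leaves the exchange of 4-acetamidophenyl for 3-(trifluoromethyl)phenyl without a size or direction in this series. No accompanying measurement offers an explanation for the result.

As far as these compounds go, whether an amine or a methoxy group in place of that hydroxy, or a carboxylic acid in place of the trifluoromethyl group on the phenyl ring, would move the number beyond the scatter remains open. Also open is whether the hydroxy step would look the same with 4-acetamidophenyl on the nitrogen, the only other group shown at that place.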